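Lengthening the Terminal Arm of a Linear Triamine

The source may hold more compounds than are shown below. What is called first, only, known or untested is meant among the compounds shown, and "the series" means these compounds.

Compound 1 `CCCNCCCNCCCN` stands at the highest of the two numbers measured in a functional assay on L1210 cells (Mus musculus) for inhibition, with a stated time of 96 h; a higher number here means a weaker inhibitor, a lower number a stronger inhibitor: in this assay compound 1 gives 100000 nM. Among the compounds with values here, its only neighbour is compound 2 `CCNCCCCNCCCN`, which in this assay gives 40000 nM, so that the step of a 2.5-fold lower number from compound 1 to compound 2 (0.40 log units; beyond the scatter) is the single measured step available, and it reads as a modest gain.

Compound 3 `CCCNCCCNCCCCN` differs from compound 1 by aminomethyl in place of amino on a saturated chain carbon, three bonds along the chain from an amine nitrogen. The measured step from compound 1 to compound 2 bears on this only loosely, since it too redistributes the saturated carbons along the chain while keeping the amine count unchanged; it therefore sets a rough ceiling of a modest step. The direction is uncertain, and a step within or only just beyond the scatter, leaning toward a lower number, is expected. Compound 3 is estimated at 60000 nM, in the range 20000 nM to 200000 nM, an expected step of a 1.7-fold lower number from compound 1 to compound 3 (0.22 log units; within the scatter).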

Compound 3, half-maximal inhibitory concentration: 28000 nM
Compound 3: middle estimate off by 2.1-fold (0.33 log units), on the high side; low and high end bracket the measured number.
By their numbers in this assay, from the lowest: compounds 3 and 2 (each within the scatter of the next); then compound 1.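

In this assay, aminomethyl in place of amino on a saturated chain carbon, three bonds along the chain from an amine nitrogen, gives a 3.6-fold lower number from compound 1 to compound 3 (0.55 log units; beyond the scatter). Within the data shown here, the only step available before this one replaced propylamino with (ethylamino)methyl, so compound 3 shows that a second, different change to compound 1 also lowers the number by more than the scatter, with both steps modest and neither going against this direction. The evidence at hand offers nothing that accounts for this step.

From the compounds shown here alone, it remains open whether a still longer chain, such as 2-aminoethyl or 3-aminopropyl in place of amino, would lower the number further or reverse the step. Going by these compounds, it is equally open whether the amine itself matters at this position, which a hydroxyl group in its place would test.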